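Adding a second 2-hydroxyethyl group to compound 2

The source may report more compounds than this note shows. Statements on the series, on what has been measured and on what is new or still open speak of the compounds shown alone.

Compound 1 `COc1cc(NC(C)CCCNC(=O)NNC(=O)NCCCCCO)c2ncccc2c1`, compound 2 `COc1cc(NC(C)CCCNC(=O)NNC(=O)NCCO)c2ncccc2c1` and compound 3 `COc1cc(NC(C)CCCNC(=O)NNC(=O)NCCNC(c2ccccc2)(c2ccccc2)c2ccccc2)c2ncccc2c1` share a core and differ in one part. In a functional assay on MOLT-4 cells (Homo sapiens) for inhibition, read by MTT assay, with a stated time of 4 days (on this read-out higher numbers stand for weaker inhibition and lower numbers for stronger inhibition), compound 1 gives >= 250000 nM, which is a limit of the assay and not a number. Compound 2 gives > 250000 nM, also a limit. Compound 3 gives a true number, 8000 nM. Compound 2 therefore has no measured potency to build on, only a limit.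

Compound 4 `COc1cc(NC(C)CCCNC(=O)NNC(=O)N(CCO)CCO)c2ncccc2c1` differs from compound 2 by this change: 2-hydroxyethyl in place of hydrogen on an amide-type nitrogen. Among the compounds with values here, the one measured step nearby, a step that the two limits leave unreadable from compound 1 to compound 2, is a different change and offers no size to carry over. The entering 2-hydroxyethyl is the same group that compound 2 already carries on that nitrogen, and that compound reads > 250000 nM in this assay. The expected step is a number no higher from compound 2 to compound 4 (the limit leaves the size open), with no clear move expected in either direction. Compound 4 is estimated at 250000 nM, with an expected range of 120000 nM to 500000 nM, and the assay will probably report only a limit again.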

Compound 4, half-maximal inhibitory concentration: > 250000 nM
Compound 4: a limit, no number (the forecaster's own chance of this, stated with the estimate: 80%); the middle value sits exactly at the limit.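

Within the data shown here, compound 1, compound 2 and compound 4 each read only as a limit of the assay, not a number, and no step among them can be read. The compounds shown leave open how far apart these three truly lie in this assay.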